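This account rests on a few compounds, and the source may have more. Where it says the series, first, only, none or still open, it means among the compounds named here.

- compound 1 `COc1c(N2CCN(C/C(C)=N/NC(N)=O)C(C)C2)c(F)cc2c(=O)c(C(=O)O)cn(C3CC3)c12`: 500 ug/mL
- compound 2 `COc1c(N2CCN(C/C(C)=N/NC(C)=O)C(C)C2)c(F)cc2c(=O)c(C(=O)O)cn(C3CC3)c12`: 707 ug/mL

In an ADME assay on Vero cells (Chlorocebus sabaeus) for cytotoxicity, read by MTT assay, with a stated time of 72 h (on this read-out lower numbers stand for higher toxicity in this test and higher numbers for lower toxicity in this test), compound 2, at 707 ug/mL, stands level with compound 1 within the scatter. Compound 3 `COc1c(N2CCN(CC/C(C)=N/O)C(C)C2)c(F)cc2c(=O)c(C(=O)O)cn(C3CC3)c12` carries a group of 5 heavy atoms (3 carbon, 1 nitrogen, 1 oxygen; no ring) in place of a group of 7 heavy atoms (4 carbon, 2 nitrogen, 1 oxygen; no ring), on a saturated chain carbon bound to an amine nitrogen in a ring. For the measured compounds named here, the only measured step, a 1.4-fold higher number from compound 1 to compound 2 (0.15 log units; within the scatter), exchanges methyl for amino on a carbonyl carbon, so it bears on this different change only indirectly, and no measured step covers the change itself. No shift beyond the scatter is therefore expected in this assay, in either direction. The expected size of the change is a 1.2-fold lower number from compound 2 to compound 3 (0.07 log units; within the scatter). For compound 3 the estimate is 600 ug/mL, with an expected range from 280 ug/mL to 1250 ug/mL.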

Compound 3, half-maximal cytotoxic concentration: 44.2 ug/mL
Compound 3: middle estimate off by 14-fold (1.13 log units), on the high side; measured number outside the range, below it.
By their numbers in this assay, from the lowest: compound 3; then compounds 1 and 2 (each within the scatter of the next).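

In this assay the change gives a 16-fold lower number from compound 2 to compound 3 (1.20 log units; beyond the scatter) and an 11-fold lower number from compound 1 to compound 3 (1.05 log units; beyond the scatter) and so shows that the group on a saturated chain carbon bound to an amine nitrogen in a ring can move the read-out beyond the scatter, which the change on the carbonyl carbon did not do. Both steps point towards higher toxicity in this test and end in the group of 5 heavy atoms (3 carbon, 1 nitrogen, 1 oxygen; no ring). Nothing available accounts for this result. Going by these compounds, it remains open whether an amine or a carboxylic acid at this place would stand with compound 3 or with compound 2.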